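From Compound 3 to Compound 4 in a Cytotoxicity Test

The source may report more compounds than this note shows. Statements on the series, on what has been measured and on what is new or still open speak of the compounds shown alone.

Measured compounds:
compound 1 `CC(Sc1nnc(-c2ccncc2)s1)C(=O)NCc1ccc(Cl)cc1`: "not determined" (no result reported)
compound 2 `O=C(CSc1nnc(-c2ccncc2)s1)Nc1ccc(Cl)cc1Cl`: "not determined" (no result reported)
compound 3 `O=C(CSc1nnc(-c2ccncc2)s1)NCc1ccc(Cl)cc1`: > 50000 nM

Of the three, only compound 3 has a result in an ADME assay on BHK-21 cells (Mesocricetus auratus) for cytotoxicity, with a stated time of 3 days; on this read-out lower numbers stand for higher toxicity in this test and higher numbers for lower toxicity in this test. That result for compound 3 is a limit of the assay, > 50000 nM, and not a number; it is the limit (the limit of > 50000 nM in this assay, at which 1 of the 3 values shown sits). For the measured compounds named here, compound 1 and compound 2 carry no result, so no step between measured compounds can be counted here.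

Compound 4 `O=C(CSc1nnc(-c2ccncc2)s1)Nc1ccccc1Cl` differs from compound 3 in one place: 2-chlorophenyl in place of 4-chlorobenzyl on an amide-type nitrogen, in words 2-chlorophenyl in place of 4-chlorobenzyl on an amide-type nitrogen. Going by the values given here, with no measured step of this kind to lean on, the expectation is a step of no size beyond the usual scatter, most likely ending again at the limit. Compound 4 is therefore expected to give 60000 nM (between 20000 nM and 200000 nM). The step this estimate implies is expected to be a step that the limit leaves unreadable from compound 3 to compound 4.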

Compound 4, half-maximal cytotoxic concentration: > 50000 nM
Compound 4: no number, only a limit; the forecaster's own chance of this, stated with the estimate: 75%; the middle value is on the limit's open side.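

For compound 3 and compound 4, this assay gives only limits of the assay, so no step can be read between them: the limit of > 50000 nM in this assay, at which 2 of the 4 values shown sit.

The compounds shown leave open whether 2-chlorophenyl in place of 4-chlorobenzyl on an amide-type nitrogen changes this read-out at all.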